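Regioisomeric dichlorophenyl sulfonamides: one cytotoxicity read-out

A few compounds are considered here, and "the series" means these few. Any claim that something is new, unique, unknown or untested is made for them only; others in the source may bear on it.

Measured compounds:
Compound 1, `O=C(CCC(NS(=O)(=O)c1cc(Cl)ccc1Cl)C(=O)NCc1ccccc1)NCc1ccccc1`: 13.4%
Compound 2, `O=C(CCC(NS(=O)(=O)c1ccc(Br)cc1)C(=O)Nc1ccccc1)Nc1ccccc1`: 10%

In a functional assay on IMR-32 cells (Homo sapiens) for cytotoxicity, read by MTT assay, tested at 60 ug/mL (a lower number here means less inhibition, a higher number more inhibition at the concentration tested (going by the name of the read-out)), compound 1 gives 13.4%. Compound 2, which carries a different aryl sulfonyl group and anilide rather than benzylamide ends, gives 10% in this assay. The gap between compound 1 and compound 2 lies within the usual scatter of such measurements, so neither stands apart from the other, and both numbers are low.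

Compound 3, `O=C(CCC(NS(=O)(=O)c1ccc(Cl)c(Cl)c1)C(=O)NCc1ccccc1)NCc1ccccc1`, has not been measured in this assay. It keeps every atom of compound 1 and changes only how two chlorine atoms sit on the aryl ring: 3,4-dichlorophenyl in place of 2,5-dichlorophenyl on a sulfonyl sulfur. Among the compounds with values here, no measured pair shows the effect of moving chlorine atoms within this ring, so the expectation rests on compound 1 alone. The step of a number 0.4 percentage points lower from compound 1 to compound 3 (within the scatter) is expected to stay within the scatter. Compound 3 is therefore estimated at 13%, with a range from 3% to 26%.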

Compound 3, a percentage reported as inhibition, at one concentration (the size of the read-out at that concentration, not a potency): 11.4%
Beside the measured number, compound 3's estimate is 1.6 percentage points above it, within the range that was stated.
By their numbers in this assay, from the lowest: compounds 2, 3 and 1 (each within the scatter of the next).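

In this assay, within the data shown here, the exchange of 2,5-dichlorophenyl for 3,4-dichlorophenyl on a sulfonyl sulfur gives a number 2 percentage points lower from compound 1 to compound 3 (within the scatter) and so provides the first reading of a single change at this position. With the rest of the molecule held constant, this rearrangement of the two chlorine atoms does not separate the two compounds, and both readings remain low at the one concentration tested. No other measurement is available that bears on this result.

The compounds shown leave open whether an unsubstituted phenyl ring, a methoxy group, a nitrile or a carboxylic acid on this ring would read differently from the dichlorophenyl groups. They also leave open how the benzylamide ends alone contribute, since compound 2 differs from the others in more than one place.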